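This account rests on a few compounds, and the source may have more. Where it says the series, first, only, none or still open, it means among the compounds named here.

Working notes on the series. In a functional assay on MGC-803 cells (Homo sapiens) for inhibition, read by MTT assay, with a stated time of 72 h (on this read-out higher numbers stand for weaker inhibition and lower numbers for stronger inhibition), compound 1 `C#CCSc1nc(Nc2ccc(OC)cc2)c(C#N)c(-c2ccccc2)n1` gives 28400 nM. Compound 2 `C#CCSc1nc(Nc2ccc(Cl)cc2)c(C#N)c(-c2ccccc2)n1` reaches only the limit of > 128000 nM in this assay, at which 1 of the 3 values shown sits, in this assay, a limit and not a number; compound 2 is recorded at > 128000 nM. Going by the values given here, the one measured step, an at least 4.5-fold higher number from compound 1 to compound 2 (0.65 log units; beyond the scatter), is the only step on this read-out. Compound 3 `N#Cc1c(Nc2cccc(C(F)(F)F)c2)nc(SCc2cn(Cc3ccccc3Cl)nn2)nc1-c1ccccc1` gives 22800 nM in this assay, the lowest of the two numbers, with compound 1 within the scatter of it. Compound 4 `Cc1cccc(Nc2nc(SCc3cn(Cc4ccccc4Cl)nn3)nc(-c3ccccc3)c2C#N)c1` differs from compound 3 by methyl in place of trifluoromethyl on an aromatic carbon. Among the compounds with values here, no measured step touches a methyl or trifluoromethyl group, and the step from compound 1 to compound 2 concerns another ring position and other groups, so it bears only loosely here. The expectation is therefore a step of a 1.3-fold higher number from compound 3 to compound 4 (0.12 log units; within the scatter), within or near the scatter. Compound 4 is estimated at 30000 nM, between 10000 nM and 100000 nM.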

Compound 4, half-maximal inhibitory concentration: 16200 nM
Estimate against measurement, compound 4: 1.9-fold (0.27 log units) above; low and high end bracket the measured number.
By their numbers in this assay, from the lowest: compounds 4, 3 and 1 (each within the scatter of the next). At a limit, above all of these: compound 2.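

In this assay the change to methyl gives a 1.4-fold lower number from compound 3 to compound 4 (0.15 log units; within the scatter), so at this aromatic carbon, going from the four heavy atoms of trifluoromethyl to the one of methyl leaves the number unchanged within the scatter. Going by these compounds alone, this is the first reading at this position, and it shows that the two groups cannot be told apart here. No measured property at hand bears on this step.

From the compounds shown here alone, whether an amine or a carboxylic acid at this position would move the number beyond the scatter stays open. So does whether the same swap would read alike on the core of compound 1.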